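Swapping the Amine on a Dithiocarbamate Side Chain

The source may report more compounds than this note shows. Statements on the series, on what has been measured and on what is new or still open speak of the compounds shown alone.

Measured compounds:
- Compound 1, `Cc1ccc2c(=O)c(CSC(=S)N(C(C)C)C(C)C)coc2c1`: 700 nM
- Compound 2, `O=c1c(CSC(=S)N2CCCCC2)coc2cc(Cl)ccc12`: 280 nM

Both compounds were tested in a functional assay on HEp-2 cells (Homo sapiens) for antiproliferative activity, read by MTT assay, with a stated time of 72 h; a lower number here means a stronger inhibitor, a higher number a weaker inhibitor. Compound 1 gives 700 nM, and compound 2 gives 280 nM. Of the two numbers, compound 2 has the lower one, and the gap to compound 1 is larger than the usual scatter, so compound 2 counts as the stronger inhibitor of the pair. The two compounds differ in two places at once, on the shared core and on the amine of the dithiocarbamate side chain, so neither difference can be read off on its own.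

Compound 3, `CC(C)N(C(=S)SCc1coc2cc(Cl)ccc2c1=O)C(C)C`, has not yet been measured. It keeps the core of compound 2 and changes only the amine: diisopropylamino in place of piperidin-1-yl on a thiocarbonyl carbon. For the measured compounds named here, no measured pair shows this single change, so its effect is unknown here. Given that compound 1 already carries diisopropylamino and gives 700 nM, a step of modest size from compound 2 to compound 3 is expected, perhaps toward a somewhat higher number, but not clearly beyond the scatter, so that a 1.5-fold higher number from compound 2 to compound 3 (0.18 log units; within the scatter) is the expected step. Compound 3 is therefore estimated at 420 nM in this assay, with a likely range from 200 nM to 900 nM.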

Compound 3, half-maximal inhibitory concentration: 4200 nM
Estimate against measurement, compound 3: 10-fold (1.00 log units) below; measured number outside the range, above it.
By their numbers in this assay, from the lowest: compound 2; then compound 1; then compound 3.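

With the core of compound 2 held fixed, diisopropylamino in place of piperidin-1-yl on a thiocarbonyl carbon gives a 15-fold higher number from compound 2 to compound 3 (1.18 log units; beyond the scatter) in this assay, so the choice of amine at this carbon clearly matters, even though both groups have no hydrogen-bond donors or acceptors and no net charge. With diisopropylamino held fixed, chloro in place of methyl on an aromatic carbon gives a 6.0-fold higher number from compound 1 to compound 3 (0.78 log units; beyond the scatter) in this assay, so the change on the core also moves the number on its own, and chloro does not give the lower number in this pair. No measurement shown here gives a reason for either step.

The compounds shown cannot say whether the lower number of compound 2 comes from having a ring in the amine or is particular to piperidin-1-yl, a question that open-chain diethylamino or ring-bearing morpholin-4-yl on the same carbon could help settle. As far as these compounds go, it also stays open whether chloro in place of methyl would move the number the same way with piperidin-1-yl on the side chain.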